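Thiophene series: aryl variation and a pyrazole replacement

The source may hold more compounds than are shown below. What is called first, only, known or untested is meant among the compounds shown, and "the series" means these compounds.

Measured so far:
compound 1 `CC(C)(C)Cc1c(-c2cc(F)ccc2F)sc(N)c1C(=O)c1ccc(Cl)cc1` — 3%
compound 2 `COc1cccc(-c2sc(N)c(C(=O)c3ccc(Cl)cc3)c2CC(C)(C)C)c1` — 1%
compound 3 `COc1ccccc1-c1sc(N)c(C(=O)c2ccc(Cl)cc2)c1CC(C)(C)C` — 1%

All three compounds share one core and differ only in the aromatic group on the ring carbon next to the ring sulfur. In an assay on CHO cells for displacement of a labelled ligand from adenosine receptor A1 (Homo sapiens), read by scintillation counting, tested at 10 uM (on this read-out higher numbers stand for more inhibition at the one concentration tested (going by the name of the read-out) and lower numbers for less inhibition), compound 1 gives 3%, compound 2 gives 1% and compound 3 gives 1%. The steps between them are small: a number 2 percentage points lower from compound 1 to compound 2 (within the scatter), a number 2 percentage points lower from compound 1 to compound 3 (within the scatter) and no change at the digits printed from compound 2 to compound 3 (within the scatter). Compound 3 therefore stands level with compound 2 at the digits shown, the two together the lowest of the three numbers, with compound 1 only slightly higher and within the scatter.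

Compound 4 `CC(C)(C)Cc1c(-c2cn[nH]c2)sc(N)c1C(=O)c1ccc(Cl)cc1` is not yet measured. Its change from compound 3 is 1H-pyrazol-4-yl in place of 2-methoxyphenyl on an aromatic carbon. Among the compounds with values here, no measured step covers the exchange of a six-membered carbon ring for a five-membered ring with two hetero atoms; the three steps available concern only substituent changes on a phenyl group, and none of them moved this assay beyond the scatter. On that basis the expected step is a number 1 percentage points higher from compound 3 to compound 4 (within the scatter), that is, none beyond the scatter. For compound 4 the estimate in this assay is 2%, with a range from -8% to 14%.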

Compound 4, a percentage reported as inhibition, at one concentration (the size of the read-out at that concentration, not a potency): 1%
The estimate for compound 4 lay 1 percentage points above the measured number; low and high end bracket the measured number.
By their numbers in this assay, from the lowest: compounds 2, 3, 4 and 1 (each within the scatter of the next).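

Within the data shown here, the 1H-pyrazol-4-yl group is the first five-membered aromatic ring with 2 hetero atoms at this position next to the ring sulfur, and the first group here with a hydrogen-bond donor. In this assay it still stays within the scatter of all three phenyl-bearing compounds, with no change at the digits printed from compound 3 to compound 4 (within the scatter) and no change at the digits printed from compound 2 to compound 4 (within the scatter) and with a number 2 percentage points lower from compound 1 to compound 4 (within the scatter) as the third step. Exchanging substituted phenyl for this smaller heteroaromatic ring therefore gives no reading that separates the four groups, and no measurement on hand offers an explanation for the result.

Still open, as far as these compounds go, is whether a non-aromatic group at this carbon, such as a morpholine ring, a primary amine or a carboxylic acid, would move this assay beyond the scatter. From the compounds shown here alone, all four compounds also keep the neopentyl group, the amino group and the (4-chlorophenyl)carbonyl group, so the effect of exchanging the neopentyl group for a cyclohexyl ring or the chlorine atom for a methoxy group remains open, as does whether this position matters at all once either of those parts changes.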